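Chloro in Place of Hydrogen: From Compound 3 to Compound 4

The source may report more compounds than this note shows. Statements on the series, on what has been measured and on what is new or still open speak of the compounds shown alone.

Three analogues sharing one core have been tested in a functional assay on SNU-638 cells (Homo sapiens) for cytotoxicity, read by sulforhodamine B assay, with a stated time of 72 h; on this read-out higher numbers stand for weaker inhibition and lower numbers for stronger inhibition. Compound 1 `CCS(=O)(=O)Nc1cc(-c2ccc3ncnc(Nc4ccc(F)cc4F)c3c2)cnc1OC` gives 2050 nM, compound 2 `CCS(=O)(=O)Nc1cc(-c2ccc3ncnc(Nc4ccc(OC)c(OC)c4)c3c2)cnc1OC` gives 1680 nM, and compound 3 `CCS(=O)(=O)Nc1cc(-c2ccc3ncnc(Nc4cccc(C(=O)OC)c4)c3c2)cnc1OC` gives 1120 nM. Compound 3 does not stand apart from the others: the steps of a 1.8-fold lower number from compound 1 to compound 3 (0.26 log units; within the scatter) and a 1.5-fold lower number from compound 2 to compound 3 (0.18 log units; within the scatter) are both within the scatter, as is a 1.2-fold lower number from compound 1 to compound 2 (0.09 log units; within the scatter). Compound 4 `CCS(=O)(=O)Nc1cc(-c2ccc3ncnc(Nc4ccc(Cl)c(C(=O)OC)c4)c3c2)cnc1OC` differs from compound 3 by chloro in place of hydrogen on an aromatic carbon. Going by the values given here, none of the measured steps involves a chloro group; all three swap whole aryl groups on the nitrogen, and none moves the number beyond the scatter. The expected step in this assay is therefore a 1.1-fold lower number from compound 3 to compound 4 (0.05 log units; within the scatter), no shift beyond the scatter. Compound 4 is thus estimated at 1000 nM, with a likely range from 400 nM to 2500 nM.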

Compound 4, half-maximal inhibitory concentration: 2200 nM
Compound 4: the middle estimate sits 2.2-fold (0.34 log units) below what was measured; low and high end bracket the measured number.
By their numbers in this assay, from the lowest: compounds 3, 2, 1 and 4 (each within the scatter of the next).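

In this assay the single chloro, placed ortho to the methoxycarbonyl group and para to a large group, gives a 2.0-fold higher number from compound 3 to compound 4 (0.29 log units; within the scatter), so this one-atom change at this position stays inside the scatter. Set against the other aryl groups, the chloro compound also shows no clear separation: a 1.3-fold higher number from compound 2 to compound 4 (0.12 log units; within the scatter) and a 1.1-fold higher number from compound 1 to compound 4 (0.03 log units; within the scatter). Nothing shown gives a reason for these numbers. On these data alone, whether an amine or a methyl group at this same position would move the number beyond the scatter stays open.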